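A few compounds are considered here, and "the series" means these few. Any claim that something is new, unique, unknown or untested is made for them only; others in the source may bear on it.

Of the compounds shown here, two have so far been measured in a functional assay on CHO-K1 cells for antagonist activity at C-X-C chemokine receptor type 3 (Homo sapiens), read by FLIPR, with a stated time of 10 min; on this read-out higher numbers stand for weaker inhibition and lower numbers for stronger inhibition. Compound 1 `Cn1c(CN2CCN(c3ccccc3NC(=O)c3ccco3)CC2)nc2ccccc21` gives 372 nM in this assay. Compound 2 `COc1ccc(-c2nc(C(F)(F)F)sc2N2CCN(C(=O)Cn3cnc4cccnc43)[C@H](C)C2)cc1` gives 13 nM in this assay, the lower of the two numbers, and its gap to compound 1 lies beyond the usual scatter. Compound 3 `COCCOc1ncc(-c2nc(C(F)(F)F)sc2N2CCN(C(=O)Cn3cnc4cccnc43)[C@H](C)C2)cn1` has not yet been measured. It differs from compound 2 in a single place: 2-(2-methoxyethoxy)pyrimidin-5-yl in place of 4-methoxyphenyl on an aromatic carbon. The rest of the shared core, including the trifluoromethyl group, is untouched; only the group sitting on the aromatic carbon of the five-membered aromatic ring with one nitrogen and one sulfur changes. Within the data shown here, no measured pair shows what such a swap does here, so the expectation rests on compound 2 alone. A modest step is expected, most likely a small loss that may not exceed the scatter; the expected step is a 1.7-fold higher number from compound 2 to compound 3 (0.23 log units; within the scatter). Compound 3 is therefore estimated to give about 22 nM in this assay, with a likely range from 6 nM to 80 nM.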

Compound 3, half-maximal inhibitory concentration: 4.7 nM
Beside the measured number, compound 3's estimate is 4.7-fold (0.67 log units) above it; the whole stated range lies above it.
By their numbers in this assay, from the lowest: compound 3; then compound 2; then compound 1.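

In this assay, among these compounds, the exchange of 4-methoxyphenyl for 2-(2-methoxyethoxy)pyrimidin-5-yl gives a 2.8-fold lower number from compound 2 to compound 3 (0.44 log units; beyond the scatter) and so adds the first reading for this position. This aromatic carbon, next to the ring nitrogen, can carry a group of 11 heavy atoms with 4 hydrogen-bond acceptors in place of one with 8 heavy atoms and 1 acceptor, and the number still falls beyond the scatter. Nothing available here explains why the number falls.

As far as these compounds go, the ring and the chain change together, so it stays open whether the pyrimidine, the 2-methoxyethoxy chain or the two combined account for the step. Also open, from the compounds shown here alone, is what a plain methoxy on the pyrimidine, or an amine or a carboxylic acid at the end of the chain, would do to the number.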